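A few compounds are considered here, and "the series" means these few. Any claim that something is new, unique, unknown or untested is made for them only; others in the source may bear on it.

Going by the values given here, in this set compound 1 `CN(C)CC[C@H]1CCC[C@@H](c2ccccc2)C1` is the one compound with a single number: in an assay on membranes from brain for displacement of a labelled ligand from Sigma non-opioid intracellular receptor 1 (Cavia porcellus), read by scintillation counting, with a stated time of 120 min (on this read-out lower numbers stand for stronger inhibition and higher numbers for weaker inhibition), compound 1 gives 10 nM, with a further entry recorded without a number. Compound 2 `c1ccc(CNCC[C@@H]2CCC[C@@H](c3ccccc3)C2)cc1` has several entries, and in this assay compound 2 gives 1.8 nM; 2.4 nM (2 entries) (the several entries of compound 2 in this assay, 1.8 nM; 2.4 nM (2 entries)). Compound 3 `CN(C)CCC1CCCC(c2ccccc2)C1` remains unmeasured; it differs from compound 1 in that (the two compounds have the same atoms and bonds; at least one stereo element is drawn with a configuration in one of them and without one in the other: 2 of 2 stereo elements differ; a stereocentre at a saturated ring carbon is drawn S in compound 1 and without a configuration in compound 3; a stereocentre at a saturated ring carbon is drawn R in compound 1 and without a configuration in compound 3). No measured step sizes this kind of change, so a modest weakening, close to the usual scatter, is expected, with a step of a 1.5-fold higher number from compound 1 to compound 3 (0.18 log units; within the scatter). Compound 3 is estimated at 15 nM, ranging from 5 nM to 45 nM.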

Compound 3, inhibition constant: 4.2 nM
Compound 3: the middle estimate sits 3.6-fold (0.55 log units) above what was measured; the whole stated range lies above it.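

With no atom entering or leaving, the change still gives a step that can be read: a 2.4-fold lower number from compound 1 to compound 3 (0.38 log units; beyond the scatter). Going by these compounds alone, this is the first sized change at the two ring stereocentres, and it shows that the configuration as drawn in compound 1 does not give the lowest number seen for this amine. The only difference the step can be traced to is this: the fact that one of compounds 1 and 3 is drawn with a defined configuration and the other without, at the place where they differ

Which configurations compound 3 actually contains remains open, as does which of the two stereocentres carries the step. Also open, going by these compounds, is how a piperidine or a longer chain at the amine would behave with either configuration.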